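The compounds below may be only part of what the source reports. "The series", "measured", "known", "first", "only" and "open" are said of these compounds alone.

Compound 3 `C[C@@H]1CCCN1c1c(C#N)c2c(N)nc(N)nc2n1C` is the compound with the highest number among the three measured here: in an assay on isolated protein for inhibition of Leucine-rich repeat serine/threonine-protein kinase 2 (Homo sapiens), read by TR-FRET and LanthaScreen, with stated times of 50 min and 30 min, in the presence of a further agent that is not named here (a lower number here means a stronger inhibitor, a higher number a weaker inhibitor), compound 3 gives 248 nM. Its nearest neighbour is compound 1 `Cc1nn(CC2(O)COC2)cc1Nc1nc(N)c2c(C#N)c(N3CCC[C@H]3C)n(C)c2n1`, which in this assay gives 57 nM, and the furthest is compound 2 `C[C@@H]1CCCN1c1c(C#N)c2c(N)nc(Nc3cn[nH]c3)nc2n1C`, which in this assay gives 6 nM. Compound 4 `Cc1nn(C2COC2)cc1Nc1nc(N)c2c(C#N)c(N3CCC[C@H]3C)n(C)c2n1` has not yet been measured; it differs from compound 3 in one place: 3-methyl-1-(oxetan-3-yl)-1H-pyrazol-4-yl in place of hydrogen on a nitrogen on an aromatic ring.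

For the measured compounds named here, one measured step bears directly on this change. Going a 41-fold higher number from compound 2 to compound 3 (1.62 log units; beyond the scatter), so removing the pyrazolyl substituent from this nitrogen weakens inhibition strongly, and putting one back should be expected to do the reverse. Compound 1 also carries a substituted pyrazolyl group on the same nitrogen, and its number sits well below that of compound 3 though above that of compound 2, which suggests that a pyrazolyl bearing further substituents recovers much but not all of the gain seen with compound 2. Compound 4 is therefore expected to show a large drop, a 6.2-fold lower number from compound 3 to compound 4 (0.79 log units; beyond the scatter), in this assay. The estimate for compound 4 is 40 nM, with a range from 12 nM to 120 nM.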

Compound 4, half-maximal inhibitory concentration: 38 nM
For compound 4 the middle estimate is 1.1-fold (0.02 log units) above the measured one; measured number inside the range.
By their numbers in this assay, from the lowest: compound 2; then compounds 4 and 1 (each within the scatter of the next); then compound 3.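

Placing the 3-methyl-1-(oxetan-3-yl)-1H-pyrazol-4-yl group on this nitrogen in this assay gives a 6.5-fold lower number from compound 3 to compound 4 (0.81 log units; beyond the scatter) and so shows that a pyrazolyl group carrying both substituents still improves on hydrogen, while the same group in place of 1H-pyrazol-4-yl gives a 6.3-fold higher number from compound 2 to compound 4 (0.80 log units; beyond the scatter) and shows that the substituted ring does not keep all of what the unsubstituted ring provides. Exchanging the group on the aromatic nitrogen of the pyrazole gives a 1.5-fold lower number from compound 1 to compound 4 (0.18 log units; within the scatter) and thus shows no difference that this measurement can resolve between oxetan-3-yl and (3-hydroxyoxetan-3-yl)methyl. Nothing among the data given offers an explanation for these steps.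

The compounds shown do not separate the share of the methyl group from that of the oxetane-bearing substituent in the step from the unsubstituted pyrazolyl compound, since both change together. Nor do they show how a piperidin-4-yl group or a simple ethyl group on that pyrazole nitrogen would behave, or whether the tolerance seen for the two oxetane groups extends to such groups.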